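The source may report more compounds than this note shows. Statements on the series, on what has been measured and on what is new or still open speak of the compounds shown alone.

Compound 1 `OC1CCc2cccc(Nc3ncc(-c4ccccc4)o3)c2C1` and compound 2 `Cc1cccc(-c2cnc(Nc3cccc4c3CC(O)CC4)o2)c1` were both examined in an in vitro functional assay on cells for antagonist activity at transient receptor potential cation channel subfamily V member 1 (Homo sapiens), read by FLIPR and calcium flux; on this read-out lower numbers stand for stronger inhibition and higher numbers for weaker inhibition. Compound 1 gives 187 nM, and compound 2 gives 157 nM. Compound 2 thus holds the lower of the two numbers, but the step of a 1.2-fold lower number from compound 1 to compound 2 (0.08 log units; within the scatter) lies within the scatter, so the two compounds cannot be separated on this assay. Compound 3 `Cc1ccc(-c2cnc(Nc3cccc4c3CC(O)CC4)o2)cc1` remains to be measured. It differs from compound 2 in one place: 4-methylphenyl in place of 3-methylphenyl on an aromatic carbon. Among the compounds with values here, the only measured step that bears on this change is a 1.2-fold lower number from compound 1 to compound 2 (0.08 log units; within the scatter), which showed that the methyl in place of hydrogen made no difference beyond the scatter. No measured pair shows what moving the methyl within the group does, so the data give no reason to expect a shift in either direction. Compound 3 is therefore expected to show no step beyond the scatter, the estimated change being a 1.0-fold higher number from compound 2 to compound 3 (0.01 log units; within the scatter). On this assay compound 3 is estimated at 160 nM, with a range from 60 nM to 450 nM.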

Compound 3, half-maximal inhibitory concentration: 62 nM
Compound 3: the middle estimate sits 2.6-fold (0.41 log units) above what was measured; measured number inside the range.
By their numbers in this assay, from the lowest: compound 3; then compounds 2 and 1 (each within the scatter of the next).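

In this assay, the position of the methyl within the aryl group matters, which the earlier pair could not show: on the aromatic carbon next to the ring oxygen, 4-methylphenyl in place of 3-methylphenyl gives a 2.5-fold lower number from compound 2 to compound 3 (0.40 log units; beyond the scatter), a modest step beyond the scatter. Methyl in place of hydrogen on the phenyl group therefore has an outcome that depends on where the methyl sits, since the 4-methylphenyl compound gives a 3.0-fold lower number from compound 1 to compound 3 (0.48 log units; beyond the scatter), whereas the 3-methylphenyl compound stayed within the scatter of the unsubstituted one. Nothing available gives a reason for this difference.

The compounds shown leave open whether the lower number belongs to methyl itself or would also appear with other groups in the same position, such as 4-chlorophenyl, 4-methoxyphenyl or 4-ethylphenyl, and what 2-methylphenyl would give. They also leave open what the hydroxyl on the shared core contributes, since all three compounds carry it, and whether an amine or a methyl ether there would keep the number where it stands.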